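The source may hold more compounds than are shown below. What is called first, only, known or untested is meant among the compounds shown, and "the series" means these compounds.

Measured so far:
Compound 1 `C[C@@H](Nc1nccc(Cl)c1NC(=O)CC#N)c1ccc(-c2cccc(F)c2C#N)cc1`: in an in vivo ADME assay on the whole organism (strain Sprague-Dawley) for pharmacokinetics, with Rattus norvegicus as the target, at a dose of 10 mg/kg by the oral route (a higher number here means that a larger share of the oral dose reaches the circulation, a lower number that a smaller share of the oral dose reaches the circulation), compound 1 gives 80%.
Compound 2 `Cc1noc(-c2c(F)cccc2-c2ccc([C@@H](C)Nc3nccc(Cl)c3NC(=O)CC#N)cc2)n1`: in this assay compound 2 gives 62%.

Within the data shown here, compound 2 stands lowest of the two numbers; its only neighbour is compound 1, set apart by the change a number 18 percentage points lower from compound 1 to compound 2 (beyond the scatter). Compound 3 `Cc1nc(-c2c(F)cccc2-c2ccc([C@@H](C)Nc3nccc(Cl)c3NC(=O)CC#N)cc2)no1` differs from compound 2 by 5-methyl-1,2,4-oxadiazol-3-yl in place of 3-methyl-1,2,4-oxadiazol-5-yl on an aromatic carbon. Among the measured compounds shown here, no measured step pairs these two oxadiazolyl groups, so the single step seen, a number 18 percentage points lower from compound 1 to compound 2 (beyond the scatter), bears only loosely on this one. The step of a number 2 percentage points lower from compound 2 to compound 3 (within the scatter) is expected to stay within the scatter. The estimate for compound 3 in this assay is 60%, between 40% and 80%.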

Compound 3, oral bioavailability: 50%
Compound 3: middle estimate off by 10 percentage points, on the high side, within the range that was stated.
By their numbers in this assay, from the lowest: compound 3; then compound 2; then compound 1.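

The two oxadiazolyl groups have the same atoms and the same counts, yet in this assay exchanging one for the other on this aromatic carbon, ortho to a fluoro group, gives a number 12 percentage points lower from compound 2 to compound 3 (beyond the scatter). How the ring is joined therefore matters here, not just what it contains. Against the nitrile, 5-methyl-1,2,4-oxadiazol-3-yl gives a number 30 percentage points lower from compound 1 to compound 3 (beyond the scatter), so both oxadiazolyl compounds stand below compound 1.

Nothing measured here explains the difference between the two rings. On these data alone, whether an amine or a carboxylic acid at this position would give a higher or lower number remains open.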